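The compounds below may be only part of what the source reports. "The series", "measured", "known", "first", "only" and "open" are said of these compounds alone.

Series values in a functional assay on A549 cells (Homo sapiens), read by MTT assay, with a stated time of 72 h; on this read-out higher numbers stand for weaker inhibition and lower numbers for stronger inhibition:
- compound 1 `CSc1ncnc2c1c(-c1ccoc1)cn2[C@@H]1O[C@H](CO)[C@@H](O)[C@H]1O`: 280 nM
- compound 2 `CN(C)c1ncnc2c1c(-c1ccoc1)cn2[C@@H]1O[C@H](CO)[C@@H](O)[C@H]1O`: > 20000 nM

Compound 2 gives > 20000 nM, which is a limit of the assay and not a number. It therefore marks the weak end of the two compounds, with no exact position.

Compound 3 `Cc1ncnc2c1c(-c1ccoc1)cn2[C@@H]1O[C@H](CO)[C@@H](O)[C@H]1O` keeps the shared core and carries methyl in place of dimethylamino on an aromatic carbon. The change lies on a six-membered aromatic ring with 2 nitrogen, part of a fused or bridged system of two rings.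

Among the compounds with values here, one measured step bears on this: an at least 71-fold higher number from compound 1 to compound 2 (1.85 log units; beyond the scatter). That step introduced the dimethylamino group now leaving, and it was large. Only compound 2 carries dimethylamino, so its removal is expected to move the number back towards compound 1 at 280 nM. Methyl itself has no measured precedent in this assay, so full recovery is not assured and the range stays wide.

A large move to a lower number is expected, an at least 33-fold lower number from compound 2 to compound 3 (1.52 log units; beyond the scatter). For compound 3 the estimated value is 600 nM, with an expected range from 100 nM to 5000 nM.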

Compound 3, half-maximal inhibitory concentration: > 20000 nM
Compound 3 gave a limit, no number; the forecaster's own chance of this, stated with the estimate: 15%; middle value at least 33-fold (1.52 log units) from the limit.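

In this assay, the loss of activity is no longer tied to dimethylamino alone, as methyl in place of methylsulfanyl on this aromatic carbon also gives a large change: an at least 71-fold higher number from compound 1 to compound 3 (1.85 log units; beyond the scatter). Of the three groups shown at this position, only methylsulfanyl, in compound 1, gives a measurable value, so a small carbon substituent and a larger nitrogen substituent both fail to keep the activity of compound 1. Compound 3 gives > 20000 nM, which is a limit of the assay and not a number, so the step between compound 2 and compound 3 cannot be read and the two compounds cannot be ranked against each other: the limit of > 20000 nM in this assay, at which 2 of the 3 values shown sit.

On these data alone, whether the activity of compound 1 depends on the sulfur atom or on some other feature of methylsulfanyl stays open, and ethylsulfanyl, methoxy or chloro on the same carbon would help to separate these possibilities. As far as these compounds go, it also stays open how far compound 2 and compound 3 lie beyond their limits, so any real difference between dimethylamino and methyl remains hidden in this assay.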